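Notes on replacing propanoyl with ethyl

A few compounds are considered here, and "the series" means these few. Any claim that something is new, unique, unknown or untested is made for them only; others in the source may bear on it.

Compound 1 `CC(C)(C)OC(=O)c1coc(-c2ccccc2)n1`: "not determined" (no result reported)
Compound 2 `CCC(=O)c1ccccc1OC(=O)c1coc(-c2ccccc2)n1`: 1.8%
Compound 3 `O=C(Oc1ccc(Cl)cc1Cl)c1coc(-c2ccccc2)n1`: 0.8%

In a physicochemical assay for metabolic stability, read by LC-MS, in simulated gastric fluid, with a stated time of 15 min, tested at 50 uM (a higher number here means that more of the compound is left, a lower number that less of the compound is left), compound 2 stands at 1.8% and compound 3 at 0.8% as two numbers within the usual scatter of each other. Compound 1 offers no number for comparison, so compound 2 can be placed against compound 3 alone, and little of either compound is left.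

Compound 4 `CCc1ccccc1OC(=O)c1coc(-c2ccccc2)n1` has not yet been measured in this assay and differs from compound 2 in one place. That difference is ethyl in place of propanoyl on an aromatic carbon and in words it puts ethyl in place of propanoyl on an aromatic carbon, ortho to a large group.

Among the compounds with values here, no measured pair differs in one place only, so the data give no direct size for this change. Within the data shown here, the only guide is that compound 2 at 1.8% and compound 3 at 0.8% both leave little despite carrying different groups. The expected result is a number 1.2 percentage points higher from compound 2 to compound 4 (within the scatter) as a small upward move that stays within the scatter. For compound 4 the estimated value is 3% with 0.5% to 12% as the expected range.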

Compound 4, percent of the compound remaining: 2.1%
The estimate for compound 4 lay 0.9 percentage points above the measured number; low and high end bracket the measured number.
By their numbers in this assay, from the lowest: compounds 3, 2 and 4 (each within the scatter of the next).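

In this assay, within the data shown here, the pair of compound 2 and compound 4 is the first that differs in one place only, and it gives a number 0.3 percentage points higher from compound 2 to compound 4 (within the scatter). Ethyl in place of propanoyl on an aromatic carbon, ortho to a large group, therefore takes away the carbonyl and its hydrogen-bond acceptor without a shift that can be told from the scatter, and compound 4 at 2.1% still leaves little of the compound after the stated time. Nothing available on these compounds speaks to why the number stays where it is.

The compounds shown leave open whether an amine, a carboxylic acid or a longer chain such as hexyl on this aromatic carbon would give a step from compound 4 that lies beyond the scatter. Also open, from the compounds shown here alone, is whether an amide in place of the ester that joins this aromatic ring to the shared core would leave more of the compound in this assay.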